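A few compounds are considered here, and "the series" means these few. Any claim that something is new, unique, unknown or untested is made for them only; others in the source may bear on it.

Working notes on the anilino series around the shared core.

Compound 1 `Cc1ccc(NC2=CC(=O)c3nc4n(c3C2=O)[C@H]2OC[C@@H](O)[C@H]2OC4)cc1` carries a (4-methylphenyl)amino group on the double-bonded ring carbon. In a functional assay on MGC-803 cells (Homo sapiens) for inhibition, read by sulforhodamine B assay (on this read-out higher numbers stand for weaker inhibition and lower numbers for stronger inhibition), compound 1 gives 1420 nM, the lowest of the two numbers measured here. Compound 2 `O=C1C(Nc2ccccc2F)=CC(=O)c2c1nc1n2[C@H]2OC[C@@H](O)[C@H]2OC1` bears (2-fluorophenyl)amino in the same place and in this assay compound 2 gives 2000 nM; the two values lie within the scatter of each other, so no order between compound 1 and compound 2 can be read. Compound 3 `O=C1C(N2CCC2)=CC(=O)c2c1nc1n2[C@H]2OC[C@@H](O)[C@H]2OC1` replaces the arylamino group with azetidin-1-yl; in this assay compound 3 reaches only a limit of the assay, > 16000 nM. Within the data shown here, that change gives an at least 8.0-fold higher number from compound 2 to compound 3 (0.90 log units; beyond the scatter), the only step measured, and it is set by the limit of > 16000 nM in this assay, at which 1 of the 3 values shown sits.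

Compound 4 `O=C1C=C(Nc2cccc(F)c2)C(=O)c2c1nc1n2[C@H]2OC[C@@H](O)[C@H]2OC1` is not yet measured. It differs from compound 1 by 3-fluorophenyl in place of 4-methylphenyl on an amine nitrogen. Among the measured compounds shown here, no measured step covers a swap between two arylamino groups; what the data show is that compound 1 and compound 2, both arylamino compounds, sit close together, while the loss of the aryl ring in compound 3 is what moves the number. A change of substituent on a retained aryl ring is therefore expected to stay within the scatter. Compound 4 is estimated at 1600 nM (range 700 nM to 4000 nM), which means an expected step of a 1.1-fold higher number from compound 1 to compound 4 (0.05 log units; within the scatter).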

Compound 4, half-maximal inhibitory concentration: 2180 nM
Beside the measured number, compound 4's estimate is 1.4-fold (0.13 log units) below it; low and high end bracket the measured number.
By their numbers in this assay, from the lowest: compounds 1, 2 and 4 (each within the scatter of the next). At a limit, above all of these: compound 3.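

In this assay, a swap between two aryl groups on this amine nitrogen can now be read directly, with 3-fluorophenyl in place of 4-methylphenyl: a 1.5-fold higher number from compound 1 to compound 4 (0.19 log units; within the scatter). Among these compounds, this is the first measured step in which the arylamino group is kept and only the aryl group changes, and it does not go beyond the scatter. Compound 1, compound 2 and compound 4 therefore stand as three arylamino compounds with no readable order among them, while compound 3, which has azetidin-1-yl in this place, stays apart at a limit of the assay: the limit of > 16000 nM in this assay, at which 1 of the 4 values shown sits.

The three aryl groups shown are 4-methylphenyl, 2-fluorophenyl and 3-fluorophenyl, so the effect of the substituent cannot be separated from that of its place on the ring. As far as these compounds go, it remains open how a methoxy group, a nitrile or a trifluoromethyl group on the aryl ring would read, and whether an open-chain amine such as dimethylamine or a larger ring such as piperidine would read like azetidin-1-yl.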